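The source may report more compounds than this note shows. Statements on the series, on what has been measured and on what is new or still open speak of the compounds shown alone.

Compound 1 `CC(C)C[C@H](N)C(=O)NS(=O)(=O)OC[C@H]1OC[C@@H](n2cnc3c(N)ncnc32)[C@H](O)[C@@H]1O` is measured in a functional assay on PBMC cells (Homo sapiens) for inhibition (on this read-out higher numbers stand for weaker inhibition and lower numbers for stronger inhibition), where it gives 1000 nM. That places compound 1 second highest of the three numbers: compound 3 `Nc1ncnc2c1ncn2[C@@H]1O[C@H](COS(=O)(=O)NC(=O)[C@@H]2CCCN2)[C@@H](O)[C@H]1O` gives 700 nM, a gap within the scatter, while compound 2 `CC[C@H](C)[C@H](N)C(=O)NS(=O)(=O)OC[C@H]1O[C@@H](n2cnc3c(N)ncnc32)[C@H](O)[C@@H]1O` gives 5600 nM, a gap beyond it. Within the data shown here, the one single-point step recorded, an 8.0-fold lower number from compound 2 to compound 3 (0.90 log units; beyond the scatter), changes the acyl substituent on the carbonyl carbon of a core different from that of compound 1, and it shows that this part of the molecule can move the read-out by a modest but real amount.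

Compound 4 `C[C@H](N)C(=O)NS(=O)(=O)OC[C@H]1OC[C@@H](n2cnc3c(N)ncnc32)[C@H](O)[C@@H]1O` differs from compound 1 by hydrogen in place of isopropyl on a saturated chain carbon, two bonds along the chain from an amine nitrogen and a carbonyl carbon. Among the measured compounds shown here, no measured step removes an alkyl branch in this way, so the direction must be inferred only loosely from the fact that the acyl substituent mattered in the step from compound 2 to compound 3. Compound 4 is therefore expected to show a 2.5-fold higher number from compound 1 to compound 4 (0.40 log units; beyond the scatter), with the sign uncertain. The estimate for compound 4 in this assay is 2500 nM, with a range from 400 nM to 15000 nM.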

Compound 4, half-maximal inhibitory concentration: 300 nM
Compound 4: middle estimate off by 8.3-fold (0.92 log units), on the high side; measured number below the stated range.
By their numbers in this assay, from the lowest: compound 4; then compounds 3 and 1 (each within the scatter of the next); then compound 2.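

The change gives a 3.3-fold lower number from compound 1 to compound 4 (0.52 log units; beyond the scatter) in this assay, so on the core of compound 1 the isopropyl on this saturated chain carbon is not needed for the read-out, and the shorter methyl chain gives the stronger inhibition of this pair. The earlier step replaced a whole acyl substituent on a different core, whereas this one keeps the core fixed and alters only the isopropyl, which gives the first direction for this position. Nothing at hand accounts for the size or direction of this step.

From the compounds shown here alone, it remains open how an ethyl group or a carboxylic acid in place of that hydrogen would read on the same core. Going by these compounds, it is also open whether the same change on the core of compound 2 and compound 3 would run the same way.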